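The source may hold more compounds than are shown below. What is called first, only, known or untested is meant among the compounds shown, and "the series" means these compounds.

Of the compounds shown here, three have been measured in a physicochemical assay for lipophilicity, read by HPLC, measured as chromatographic lipophilicity, at pH 7.4; a higher number here means a more lipophilic compound, a lower number a more polar compound. Compound 2 `CC(C)(C)C(=O)N1CCSC1c1ccccc1` gives 5.6, and compound 3 `O=C(c1cccnc1)N1N=CCC1c1ccccc1` gives 2.7. Compound 1 `N#Cc1ccc(N2CCC(C(=O)N3N=CC[C@H]3c3cc(F)cc(F)c3)CC2)nn1`, at 4.8, stands second highest of the three. Its nearest neighbour is compound 2, which lies above it by more than the usual scatter, while compound 3 lies furthest away, below it and also well beyond the scatter.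

Compound 4 `Cc1nnc(N2CCC(C(=O)N3N=CC[C@H]3c3cc(F)cc(F)c3)CC2)o1` keeps the rest of compound 1 and differs in one place, on the amine nitrogen in a ring: a group of 6 heavy atoms (3 carbon, 2 nitrogen, 1 oxygen; one five-membered aromatic ring with 3 hetero atoms) in place of a group of 8 heavy atoms (5 carbon, 3 nitrogen; one six-membered aromatic ring with 2 hetero atoms), on an amine nitrogen in a ring. There, 5-methyl-1,3,4-oxadiazol-2-yl takes the place of a group with a six-membered aromatic ring, so a group of 6 heavy atoms replaces a group of 8 heavy atoms.

Among the compounds with values here, no two measured compounds differ in only one place, so no measured step gauges this exchange. The expectation therefore rests on the structural change alone, starting from compound 1 at 4.8. A modest fall in this assay is expected, somewhat beyond the scatter, although a change within the scatter remains possible. The estimate amounts to a step of a number 0.50 log units lower from compound 1 to compound 4 (beyond the scatter). Compound 4 is expected at 4.3, with an estimated range from 3.7 to 4.9.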

Compound 4, distribution coefficient: 3.6
Compound 4: middle estimate off by 0.70 log units, on the high side; the measured number lies below the stated range.
By their numbers in this assay, from the lowest: compound 3; then compound 4; then compound 1; then compound 2.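

Within the data shown here, this position on the amine nitrogen in a ring now has a measured step: with 5-methyl-1,3,4-oxadiazol-2-yl in place of the group with a six-membered aromatic ring, this assay gives a number 1.20 log units lower from compound 1 to compound 4 (beyond the scatter), a large step and the only one so far between compounds that differ in one place. The step shows that this single exchange on the shared core moves the number well beyond the scatter, even though the two groups have the same counts of hydrogen-bond donors and acceptors and neither has a net charge. Nothing at hand explains the size of the step.

The exchange alters the ring size, removes the triple bond and adds a methyl group all at once, so the contribution of each change remains unresolved. From the compounds shown here alone, an unsubstituted 1,3,4-oxadiazol-2-yl, a plain phenyl ring or a six-membered aromatic ring carrying a methyl group in place of the nitrile on the same amine nitrogen would begin to separate these contributions, and whether the step holds on another core also remains open.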